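Cytotoxicity notes on a benzyl-imidazole series, compound 2 to 3

The source may report more compounds than this note shows. Statements on the series, on what has been measured and on what is new or still open speak of the compounds shown alone.

Measured so far:
- compound 1 `Clc1ccc(NCc2cncn2Cc2ccc(-c3ccccc3)cc2)cc1-c1ccccc1`, > 1000 nM
- compound 2 `COC(=O)c1ccc(NCc2cncn2Cc2ccccc2N)cc1-c1ccccc1`, 25000 nM

In a toxicity assay on NIH3T3 cells (Mus musculus) for cytotoxicity, read by resazurin assay (on this read-out higher numbers stand for an effect only at larger amounts of compound and lower numbers for an effect already at smaller amounts), compound 1 gives > 1000 nM, which is a limit of the assay and not a number. In this assay, going by the values given here, compound 2 gives 25000 nM, the only number so far. The other value, that of compound 1, is a limit (the limit of > 1000 nM in this assay, at which 1 of the 2 values shown sits). Compound 2 therefore carries the single numerical reference in the set.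

Compound 3 `COC(=O)c1ccc(NCc2cncn2Cc2ccccc2C#N)cc1-c1ccccc1` is not yet measured. It differs from compound 2 by one change (cyano in place of amino on an aromatic carbon). Among the compounds with values here, no step between measured compounds is available to calibrate this change.

Within the data shown here, with only one number in hand, the step from compound 2 to compound 3 is expected to be none beyond the scatter, so that the expected change is no change at the digits printed from compound 2 to compound 3 (within the scatter). Compound 3 is estimated at 25000 nM, within a range from 8000 nM to 80000 nM. The wide range reflects that a single value, that of compound 2 at 25000 nM, is the only anchor.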

Compound 3, half-maximal effective concentration: 25000 nM
Estimate against measurement, compound 3: no gap at the digits printed, and the stated range covers the measured number.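

Going by these compounds alone, exchanging 2-aminobenzyl for 2-cyanobenzyl gives no change at the digits printed from compound 2 to compound 3 (within the scatter) in this assay, the first step that can be read at all. The exchange removes a hydrogen-bond donor, adds one heavy atom and brings in a triple bond outside aromatic rings, yet at this place, on an aromatic carbon ortho to a large group, the read-out shows no difference between the two compounds. Steps to compound 1 cannot be read, and that compound, whose value is a limit and not a number, adds no second numerical anchor: the limit of > 1000 nM in this assay, at which 1 of the 3 values shown sits.

Still open, as far as these compounds go, is whether other groups at this place, such as a carboxylic acid, a methoxy group or a longer chain ending in an amine, would also leave the read-out in this assay where it stands, since a single step between two compounds sets no pattern for the position. Also open, from the compounds shown here alone, is how the methyl ester shared by compound 2 and compound 3 bears on this read-out, which a carboxylic acid or a primary amide in its place would test.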